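Swapping the aryl ring on the hydrazone carbon

The compounds below may be only part of what the source reports. "The series", "measured", "known", "first", "only" and "open" are said of these compounds alone.

Measured so far in a functional assay on PC-3 cells (Homo sapiens) for antiproliferative activity, read by MTT assay; on this read-out lower numbers stand for stronger inhibition and higher numbers for weaker inhibition:
compound 1 `Cn1c(=O)c(=O)n(C2CCCC2)c2nc(N/N=C/c3ccc(F)c(Cl)c3)ncc21` gives 8550 nM
compound 2 `Cn1c(=O)c(=O)n(C2CCCC2)c2nc(N/N=C/c3ccc(O)c(F)c3)ncc21` gives 85200 nM
compound 3 `COc1ccc(/C=N/Nc2ncc3c(n2)n(C2CCCC2)c(=O)c(=O)n3C)c(OC)c1` gives only a limit of the assay, > 100000 nM

Compound 1 has the lowest of the two numbers; compound 2 sits a 10-fold higher number from compound 1 to compound 2 (1.00 log units; beyond the scatter) away. Compound 3 is known only as a limit. Compound 4 `Cn1c(=O)c(=O)n(C2CCCC2)c2nc(N/N=C/c3ccc(F)cc3F)ncc21` is not yet measured; it differs from compound 1 by 2,4-difluorophenyl in place of 3-chloro-4-fluorophenyl on a carbon with a double bond to nitrogen. The measured steps that bear on this change are a 10-fold higher number from compound 1 to compound 2 (1.00 log units; beyond the scatter) and an at least 11-fold higher number from compound 1 to compound 3 (1.06 log units; beyond the scatter), both toward weaker inhibition, yet both bring a hydroxyl or methoxy group, whereas compound 4 keeps halogens only. A smaller weakening is expected, a 1.8-fold higher number from compound 1 to compound 4 (0.24 log units; within the scatter). For compound 4 the estimate is 15000 nM, with a range from 5000 nM to 60000 nM.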

Compound 4, half-maximal inhibitory concentration: 13200 nM
Compound 4: middle estimate off by 1.1-fold (0.06 log units), on the high side; low and high end bracket the measured number.
By their numbers in this assay, from the lowest: compounds 1 and 4 (each within the scatter of the next); then compound 2. At a limit, above all of these: compound 3.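

In this assay, 2,4-difluorophenyl in place of 3-chloro-4-fluorophenyl gives a 1.5-fold higher number from compound 1 to compound 4 (0.19 log units; within the scatter), so this swap between halogen-only rings leaves no readable change. Set against the rings with a hydroxyl or methoxy group, the new compound gives a 6.5-fold lower number from compound 2 to compound 4 (0.81 log units; beyond the scatter) and an at least 7.5-fold lower number from compound 3 to compound 4 (0.87 log units; beyond the scatter), so among these compounds the weaker results go with those two rings. The value for compound 3 is only a limit: the limit of > 100000 nM in this assay, at which 1 of the 4 values shown sits.

Still open, as far as these compounds go, is how a plain phenyl ring, or one carrying an amine or a nitrile, would compare, and so whether halogens are needed here at all.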